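The compounds below may be only part of what the source reports. "The series", "measured", "known", "first", "only" and "open" are said of these compounds alone.

Measured so far in a functional assay on KYSE-410 cells (Homo sapiens) for antiproliferative activity, read by MTT assay, with a stated time of 72 h; on this read-out higher numbers stand for weaker inhibition and lower numbers for stronger inhibition:
- Compound 1 `O=C(Nc1ccc(Cl)cc1)c1ccnc2cc(Br)ccc12`: > 20000 nM (a limit)
- Compound 2 `O=C(Nc1cccc(F)c1)c1cc(=O)[nH]c2cc(-c3ccccc3)ccc12`: > 20000 nM (a limit)

No number is available for either compound. The position of the series in this assay is summed up as the limit of > 20000 nM in this assay, at which 2 of the 2 values shown sit. Compound 2 therefore has no defined potency, and its reading of > 20000 nM is only a limit.

The next compound is compound 3 `O=C(Nc1cccc(F)c1)c1cc(=O)[nH]c2cc(-c3cccc(F)c3)ccc12`. It differs from compound 2 by fluoro in place of hydrogen on an aromatic carbon, which turns phenyl to 3-fluorophenyl: fluoro in place of hydrogen on an aromatic carbon. The new atom sits on a six-membered aromatic ring of carbon only, meta to a large group.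

Within the data shown here, no step between measured compounds is available to size this change. The expectation rests on the structural change being a single atom and on the starting point of compound 2 at > 20000 nM. The expected step that the limit leaves unreadable from compound 2 to compound 3 is none beyond the usual scatter, with no direction favoured. For compound 3 the estimate is 22000 nM, with an expected range from 9000 nM to 50000 nM. A report of only a limit is the likeliest expected outcome.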

Compound 3, half-maximal inhibitory concentration: 10900 nM
Compound 3: middle estimate off by 2.0-fold (0.30 log units), on the high side; the measured number falls inside the stated range.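

In this assay, among these compounds, the change from phenyl to 3-fluorophenyl gives an at least 1.8-fold lower number from compound 2 to compound 3 (0.26 log units; that floor lies within the scatter); this is the first step that can be read, and it is readable only as a floor. Among the compounds shown here, compound 3 carries the first defined number at this position, on an aromatic carbon meta to a large group, but the floor alone does not separate this change from the scatter. The limit still accounts for most of the values shown: the limit of > 20000 nM in this assay, at which 2 of the 3 values shown sit.

As far as these compounds go, the true size of the step stays open, as the reading for compound 2 is a limit and not a number. Also open, from the compounds shown here alone, is whether a methoxy group, an amine or a carboxylic acid in place of the fluoro would give a number clearly beyond the scatter from compound 3 in this assay.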